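This account rests on a few compounds, and the source may have more. Where it says the series, first, only, none or still open, it means among the compounds named here.

The two measured compounds share one core and differ only in a single group on an aromatic carbon. Compound 1 `Cc1cc(NC(=O)Nc2ccc(Cl)cc2)c2ccccc2n1` carries a chloro group there. In an ADME assay on HEK293 cells (Homo sapiens) for cytotoxicity, with a stated time of 72 h (on this read-out higher numbers stand for an effect only at larger amounts of compound and lower numbers for an effect already at smaller amounts), compound 1 gives > 25000 nM, which is a limit of the assay rather than a number. Compound 2 `Cc1cc(NC(=O)Nc2ccc(SC(F)(F)F)cc2)c2ccccc2n1` carries a (trifluoromethyl)sulfanyl group instead, and in this assay compound 2 gives 13000 nM. Between the two there is an at least 1.9-fold lower number from compound 1 to compound 2 (0.28 log units; that floor lies within the scatter), from (trifluoromethyl)sulfanyl in place of chloro on an aromatic carbon. Among the measured compounds shown here, compound 2 thus holds the only numeric value in this assay, the other entry being (the limit of > 25000 nM in this assay, at which 1 of the 2 values shown sits).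

Compound 3 `Cc1cc(NC(=O)Nc2ccc(C(C)(C)C)cc2)c2ccccc2n1` is not yet measured. It differs from compound 2 by tert-butyl in place of (trifluoromethyl)sulfanyl on an aromatic carbon. For the measured compounds named here, only one measured step exists, and it exchanged chloro for (trifluoromethyl)sulfanyl, not for tert-butyl, so it bears on this change only loosely; even that step could not be told apart from the scatter. No step beyond the scatter is therefore expected, and the estimated change is a 1.2-fold higher number from compound 2 to compound 3 (0.06 log units; within the scatter). For compound 3 in this assay the estimate is 15000 nM, with a range from 6000 nM to 40000 nM.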

Compound 3, half-maximal effective concentration: > 25000 nM
Compound 3: only a limit was reported (the forecaster's own chance of this, stated with the estimate: 35%); at least 1.6-fold (0.22 log units) between middle value and limit.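

Replacing (trifluoromethyl)sulfanyl with tert-butyl on this aromatic carbon, para to a large group, gives in this assay an at least 1.9-fold higher number from compound 2 to compound 3 (0.28 log units; that floor lies within the scatter). This is the second readable step at this position, and like the first it does not go beyond the usual scatter, so the position has not yet been shown to alter the read-out. Compound 3 now joins compound 1 at a limit of the assay rather than a number, so the step between these two compounds cannot be read: the limit of > 25000 nM in this assay, at which 2 of the 3 values shown sit.

The compounds shown leave open how this position responds to an amine, a carboxylic acid or a longer chain, since all three groups so far give either a limit or a single value that cannot be separated from that limit. Also open, from the compounds shown here alone, is whether compound 2 truly differs from compound 1 and compound 3, which would take actual numbers for those two compounds rather than limits, or a group that moves the read-out well beyond the scatter.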